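Bromine on the pyrimidinedione ring: a small step repeated

The source may hold more compounds than are shown below. What is called first, only, known or untested is meant among the compounds shown, and "the series" means these compounds.

Measured so far in an ADME assay on L1210/0 cells (Mus musculus) for cytotoxicity, with a stated time of 48 h; a lower number here means a stronger inhibitor, a higher number a weaker inhibitor:
- compound 1, `O=C1O/C(=C\Cn2cc(Br)c(=O)[nH]c2=O)C(OCc2ccccc2)=C1OCc1ccccc1`: compound 1 gives 7500 nM
- compound 2, `O=C1O/C(=C\Cn2ccc(=O)[nH]c2=O)C(OCc2ccccc2)=C1OCc1ccccc1`: compound 2 gives 12900 nM
- compound 3, `CC1(C)[C@@H](CO)CC[C@@]1(C)Cn1ccc(=O)[nH]c1=O`: for compound 3 this assay reports only a limit, > 200000 nM

Compound 1 and compound 2 share one core and differ in a single place, (bromo in place of hydrogen on an aromatic carbon). The step that this change made is a 1.7-fold lower number from compound 2 to compound 1 (0.24 log units; within the scatter), so the two values cannot be told apart by this assay.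

Compound 3 carries a different core; how it differs from the core of compound 2 is not broken down here. Compound 4, `CC1(C)[C@@H](CO)CC[C@@]1(C)Cn1cc(Br)c(=O)[nH]c1=O`, is built from compound 3 by the same change, (bromo in place of hydrogen on an aromatic carbon), at a place described in the same words as for compound 2 and compound 1.

For the measured compounds named here, the only guide to what compound 4 will show is that earlier step, which was within the scatter, and the fact that compound 3 sits at the limit of > 200000 nM in this assay, at which 1 of the 3 values shown sits. Because compound 3 sits at the limit of > 200000 nM in this assay, at which 1 of the 3 values shown sits, a change that moved the other pair so little is expected to leave compound 4 at or near the same limit. The expected step is a step that the limit leaves unreadable from compound 3 to compound 4, set beside the measured 1.7-fold lower number from compound 2 to compound 1 (0.24 log units; within the scatter). Compound 4 is therefore expected near 300000 nM, with a plausible span from 100000 nM to 1000000 nM, and most likely this assay will again report only a limit.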

Compound 4, half-maximal inhibitory concentration: > 200000 nM
Compound 4 gave a limit, no number (the forecaster's own chance of this, stated with the estimate: 75%); the middle value is on the limit's open side.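

In this assay compound 3 and compound 4 both return only a limit, not a number, so the step between them cannot be read: the limit of > 200000 nM in this assay, at which 2 of the 4 values shown sit. The compounds shown leave open how far the true values of compound 3 and compound 4 lie past that limit, and whether bromo in place of hydrogen changes anything on this core.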